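The source may report more compounds than this note shows. Statements on the series, on what has been measured and on what is new or still open speak of the compounds shown alone.

Series values in a functional assay on A549 cells (Homo sapiens) for antiproliferative activity, read by MTT assay, with a stated time of 18 h; a higher number here means a weaker inhibitor, a lower number a stronger inhibitor:
- compound 1 `Cc1ccc(-c2cc(COc3ncnc4sc(C)cc34)on2)cc1`: 144000 nM
- compound 2 `Cc1cc2c(OCc3cc(-c4ccc(Cl)cc4)no3)ncnc2s1`: 2790 nM
- compound 3 `CCc1cc2c(OCc3cc(-c4ccc(OC)cc4)no3)ncnc2s1`: 55000000 nM

Compound 2 has the lowest of these three numbers, so it is the strongest inhibitor measured so far. Compound 4 `CC(C)(C)c1cc2c(OCc3cc(-c4ccc(Cl)cc4)no3)ncnc2s1` differs from it by tert-butyl in place of methyl on an aromatic carbon, next to the ring sulfur: tert-butyl in place of methyl on an aromatic carbon.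

Within the data shown here, the one measured step, a 52-fold lower number from compound 1 to compound 2 (1.71 log units; beyond the scatter), is large but lies at a different place, so it shows only that a single change can move this assay far. Among the measured compounds shown here, no measured step isolates the change at this carbon. Compound 3 is the nearest guide, as it differs from compound 2 in two places, one of them this same carbon, and compound 3 gives 55000000 nM. That value points towards a higher number, though its two changes cannot be separated.

A clear loss is therefore expected, with the estimated change being a 4.3-fold higher number from compound 2 to compound 4 (0.63 log units; beyond the scatter). For compound 4 the estimate is 12000 nM, with an expected range of 900 nM to 400000 nM.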

Compound 4, half-maximal inhibitory concentration: 159000 nM
The estimate for compound 4 lay 13-fold (1.12 log units) below the measured number; measured number inside the range.
By their numbers in this assay, from the lowest: compound 2; then compounds 1 and 4 (each within the scatter of the next); then compound 3.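

In this assay the aromatic carbon next to the ring sulfur now has a step of its own: tert-butyl in place of methyl gives a 57-fold higher number from compound 2 to compound 4 (1.76 log units; beyond the scatter) with the chlorophenyl side held constant. Compound 3 could only hint at this, as its two changes cannot be separated, whereas this pair ties a large loss to this carbon alone. Methyl is thus the better of the two groups compared directly here, and nothing in hand explains why the number rises.

Only methyl and tert-butyl can be compared directly at this carbon, and ethyl appears only in compound 3 alongside a second change. Going by these compounds, whether a hydrogen, an isopropyl group, a straight propyl chain or an amine at this carbon would keep the number of compound 2 stays open.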